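A new amide group on compound 3

The source may hold more compounds than are shown below. What is called first, only, known or untested is meant among the compounds shown, and "the series" means these compounds.

Compound 1 `Cn1cc(-c2cn3c(Cc4ccc5ncccc5c4)cnc3cc2Cl)cn1`: "not determined" (no result reported)
Compound 2 `Fc1cc(F)cc(-c2cc(F)c3ncc(Cc4ccc5ncccc5c4)n3c2)c1`: 790 nM
Compound 3 `O=C(c1ccc(-c2cc(F)c3ncc(Cc4ccc5ncccc5c4)n3c2)cc1F)N1CCC2(COC2)C1`: 406 nM

In a functional assay on EBC-1 cells (Homo sapiens) for antiproliferative activity, with a stated time of 72 h (on this read-out higher numbers stand for weaker inhibition and lower numbers for stronger inhibition), compound 3 gives 406 nM, which lies within the usual scatter of compound 2 at 790 nM. Compound 1 has no number to compare. Compound 4 `O=C(NCc1cc(F)cc(F)c1)c1ccc(-c2cc(F)c3ncc(Cc4ccc5ncccc5c4)n3c2)cc1F` keeps the core of compound 3 and alters only the group on the carbonyl carbon: a group of 10 heavy atoms (7 carbon, 1 nitrogen, 2 fluorine; one six-membered aromatic ring of carbon only) in place of a group of 8 heavy atoms (6 carbon, 1 nitrogen, 1 oxygen; one four-membered non-aromatic ring with 1 hetero atom, one five-membered non-aromatic ring with 1 hetero atom), on a carbonyl carbon. For the measured compounds named here, the (3,5-difluorobenzyl)amino group has no measured precedent here, and no pair of measured compounds differs in one place alone. Nothing therefore points to a clear rise or fall. The expected change is a 1.2-fold lower number from compound 3 to compound 4 (0.06 log units; within the scatter), which would stay within the scatter. The estimate for compound 4 is 350 nM, with an expected range from 80 nM to 1500 nM.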

Compound 4, half-maximal inhibitory concentration: 53.6 nM
Beside the measured number, compound 4's estimate is 6.5-fold (0.81 log units) above it; the whole stated range lies above it.
By their numbers in this assay, from the lowest: compound 4; then compounds 3 and 2 (each within the scatter of the next).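

In this assay, the group on the carbonyl carbon clearly affects the read-out: replacing the group of compound 3 with (3,5-difluorobenzyl)amino gives a 7.6-fold lower number from compound 3 to compound 4 (0.88 log units; beyond the scatter), the first step shown at this place. The exchange alters ring content, atom count and the amide hydrogen together, so the step cannot be assigned to any one of these features. No measured evidence bears on the reason for this step. The compounds shown leave open what a plain benzylamino group without fluorine, or a smaller methylamino group, would give on this carbonyl carbon.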